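The source may report more compounds than this note shows. Statements on the series, on what has been measured and on what is new or still open speak of the compounds shown alone.

Of the compounds shown here, three of a shared core have been measured in an ADME assay on HepG2 2.2.15 cells (Homo sapiens) for cytotoxicity; on this read-out higher numbers stand for lower toxicity in this test and lower numbers for higher toxicity in this test. Compound 1 `Cn1c(=O)c(CCO)c(-c2ccccc2Cl)c2cc(Cl)ccc21` gives 34000 nM in this assay, and compound 2 `C=CCn1c(=O)c(CCO)c(-c2ccccc2Cl)c2cc(Cl)ccc21` gives 23000 nM. The change from vinyl in place of hydrogen on a saturated chain carbon bound to an aromatic nitrogen is recorded as a 1.5-fold lower number from compound 1 to compound 2 (0.17 log units; within the scatter). Compound 3 `CCCCCCCC(=O)OCCc1c(-c2ccccc2Cl)c2cc(Cl)ccc2[nH]c1=O`, which carries the heptylcarbonyl ester instead of the free hydroxyl and an unsubstituted ring nitrogen, gives 78000 nM, the highest of the three numbers; the gaps to compound 1 and to compound 2 both lie beyond the scatter.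

Compound 4 `O=C(OCCc1c(-c2ccccc2Cl)c2cc(Cl)ccc2[nH]c1=O)c1ccccc1` has not yet been measured. It differs from compound 3 only at the ester: phenyl in place of heptyl on a carbonyl carbon. Among the compounds with values here, the single measured step, between compound 1 and compound 2, concerns the ring nitrogen and not the carbonyl carbon, so no measured step bears directly on this change, and that one step was anyway within the scatter. With nothing in the data pointing either way, the number for compound 4 is expected to stay close to that of compound 3, with no step beyond the scatter being predicted. The step of a 1.3-fold lower number from compound 3 to compound 4 (0.11 log units; within the scatter) is the estimated change. Compound 4 is therefore estimated to give 60000 nM, with a range from 25000 nM to 150000 nM.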

Compound 4, half-maximal cytotoxic concentration: 43000 nM
The estimate for compound 4 lay 1.4-fold (0.14 log units) above the measured number; the measured number falls inside the stated range.
By their numbers in this assay, from the lowest: compounds 2, 1, 4 and 3 (each within the scatter of the next, the first and the last beyond it).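

In this assay, within the data shown here, the result gives the first reading at the carbonyl carbon of the ester, a place the earlier step at the ring nitrogen did not touch: phenyl in place of heptyl gives a 1.8-fold lower number from compound 3 to compound 4 (0.26 log units; within the scatter). Exchanging the open heptyl chain for a six-membered aromatic ring of carbon only therefore leaves the two esters inseparable on this read-out, so this test does not distinguish heptylcarbonyl from benzoyl on this core. No measurement at hand offers an explanation for this outcome.

From the compounds shown here alone, whether a longer chain than heptyl, or an amine or a carboxylic acid carried on that carbonyl carbon, would also stay within the scatter of compound 3 remains open. Also open is what the ester and the unsubstituted ring nitrogen each contribute, as no pair shown differs in only one of those two places, so the two esters cannot yet be set in a single step against the free hydroxyl of compound 1 or compound 2.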